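A few compounds are considered here, and "the series" means these few. Any claim that something is new, unique, unknown or untested is made for them only; others in the source may bear on it.

Measured compounds:
Compound 1, `CC(N)C[Se]c1ccc(F)cc1`, gives 10500 nM in an assay on isolated protein for inhibition of Amine oxidase [flavin-containing] A (Homo sapiens), read by fluorescence and spectrophotometry; on this read-out lower numbers stand for stronger inhibition and higher numbers for weaker inhibition.
Compound 2, `CC(N)C[Se]c1ccc(N(C)C)cc1`, gives 7150 nM in this assay.
Compound 3, `Cc1ccccc1[Se]CC(C)N`, gives 5170 nM in this assay.

Compound 3 gives the lowest of the three numbers shown. Its gap to compound 2 lies within the scatter, so the two cannot be told apart, while its gap to compound 1 lies just beyond it. Compound 4, `CC(N)C[Se]c1ccccc1`, has not yet been measured. It differs from compound 3 by hydrogen in place of methyl on an aromatic carbon.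

Among the measured compounds shown here, only one measured step changes a group on the aromatic ring: a 1.5-fold lower number from compound 1 to compound 2 (0.17 log units; within the scatter). That step swaps one group for another on the ring, and the number barely moves. For the measured compounds named here, no measured step removes a methyl from the ring, so there is no direct guide to the change from compound 3 to compound 4. Given that the one ring change seen stayed within the scatter, a step of similar smallness is expected here, with no clear direction: a 1.3-fold higher number from compound 3 to compound 4 (0.10 log units; within the scatter). Compound 4 is therefore estimated at 6500 nM in this assay, with a likely range from 3000 nM to 14000 nM.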

Compound 4, half-maximal inhibitory concentration: 9790 nM
For compound 4 the middle estimate is 1.5-fold (0.18 log units) below the measured one; measured number inside the range.
By their numbers in this assay, from the lowest: compounds 3, 2, 4 and 1 (each within the scatter of the next, the first and the last beyond it).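

With hydrogen in place of methyl on this aromatic carbon, the step (a 1.9-fold higher number from compound 3 to compound 4 (0.28 log units; within the scatter)) stays inside the usual scatter, so the methyl cannot be shown to matter in this assay. Compound 4, which carries no group on the ring, also gives a reference for the other two ring groups: hydrogen in place of dimethylamino (a 1.4-fold higher number from compound 2 to compound 4 (0.14 log units; within the scatter)) and hydrogen in place of fluoro (a 1.1-fold lower number from compound 1 to compound 4 (0.03 log units; within the scatter)) are both inside the scatter as well, so neither of those groups can be told apart from hydrogen. No measured evidence explains why these steps are so small.

As far as these compounds go, it remains open whether a methoxy, a carboxylic acid or a second benzene ring on the aromatic ring would move the number beyond the scatter. From the compounds shown here alone, it is also open whether methyl on a different ring carbon would give a similar number.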